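A few compounds are considered here, and "the series" means these few. Any claim that something is new, unique, unknown or untested is made for them only; others in the source may bear on it.

Compound 3 `COc1ccc(C(=O)NOCc2ccccc2)cc1S(=O)(=O)Nc1ccc2c(c1)cc(C)c(=O)n2C` gives 13% in a functional assay on HL-60 cells (Homo sapiens) for antiproliferative activity, tested at 20 uM; a lower number here means a weaker effect, a higher number a stronger effect of the compound at the concentration tested. Compound 1 `COC(=O)c1ccc(CS(=O)(=O)Nc2ccc3c(c2)cc(C)c(=O)n3C)cc1` gives 14%, within the scatter of compound 3. Compound 2 `Cc1cc2cc(NS(=O)(=O)Cc3ccc(C(=O)NO)cc3)ccc2n(C)c1=O` gives 0%, below compound 3 by more than the scatter; of the three numbers, compound 3 is the second highest. For the measured compounds named here, the one measured single-site step, a number 14 percentage points lower from compound 1 to compound 2 (beyond the scatter), concerns a hydroxyamino entering in place of methoxy on a carbonyl carbon and is not the change considered here. Compound 4 `COc1ccc(C(=O)NOCc2ccc(OC(C)=O)cc2)cc1S(=O)(=O)Nc1ccc2c(c1)cc(C)c(=O)n2C` differs from compound 3 by acetoxy in place of hydrogen on an aromatic carbon. Going by the values given here, no measured step covers an acetoxy entering in place of hydrogen, so the small read-out of compound 3 is the only guide, and a step of no size beyond the scatter is expected, no change at the digits printed from compound 3 to compound 4 (within the scatter). Compound 4 is therefore estimated at 13%, between 0% and 30%.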

Compound 4, a percentage reported as inhibition, at one concentration (the size of the read-out at that concentration, not a potency): 0%
Compound 4: the middle estimate sits 13 percentage points above what was measured; low and high end bracket the measured number.
By their numbers in this assay, from the lowest: compounds 2 and 4 (each within the scatter of the next); then compounds 3 and 1 (each within the scatter of the next).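

In this assay, for the compounds shown here, the change from benzyloxy to (4-acetoxybenzyl)oxy gives a number 13 percentage points lower from compound 3 to compound 4 (beyond the scatter), the first measured step at this ring, where the earlier compounds covered only a change on a carbonyl carbon. The position is therefore not silent to substitution, though the step starts from a small read-out and ends with compound 4 at 0%. Nothing at hand accounts for the loss. From the compounds shown here alone, whether a hydroxy, a methoxy, an amine or a carboxylic acid at this place would give the same drop remains open. Equally open, going by these compounds, is whether acetoxy on another carbon of this ring would match it.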